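Compound 4: one fluoropyridinyl group exchanged for another

The source may hold more compounds than are shown below. What is called first, only, known or untested is meant among the compounds shown, and "the series" means these compounds.

Measured in an ADME assay on liver for metabolic stability, with Liver microsome (Homo sapiens) as the target, read by LC-MS, using microsomes, with a stated time of 5 h; on this read-out higher numbers stand for fast clearance and lower numbers for slow clearance:
- compound 1 `OC(c1ncccc1F)C1(c2ccc(Cl)c(Cl)c2)CCC1` gives 833 mL/min/kg
- compound 2 `OC(c1cc(F)ccn1)C1(c2ccc(Cl)c(Cl)c2)CCC1` gives 533 mL/min/kg
- compound 3 `O[C@H](c1ccccn1)[C@]1(c2ccnc(C(F)(F)F)c2)C[C@H](O)C1` gives 33.3 mL/min/kg

Compound 2, at 533 mL/min/kg, holds the second highest of the three numbers in this assay. It lies within the scatter of compound 1 and well beyond the scatter from compound 3 , which differs from it in more than one place.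

The next compound is compound 4 `OC(c1ccc(F)cn1)C1(c2ccc(Cl)c(Cl)c2)CCC1`, and its difference from compound 2 is 5-fluoropyridin-2-yl in place of 4-fluoropyridin-2-yl on a saturated chain carbon bound to an oxygen on a saturated carbon and a saturated ring carbon. In words, 5-fluoropyridin-2-yl stands in place of 4-fluoropyridin-2-yl on a saturated chain carbon bound to an oxygen on a saturated carbon and a saturated ring carbon.

Among the measured compounds shown here, one measured step bears on this change: a 1.6-fold lower number from compound 1 to compound 2 (0.19 log units; within the scatter). It exchanged one fluoropyridinyl group for another at the same place and stayed within the scatter. For the measured compounds named here, no measured compound carries the 5-fluoropyridin-2-yl group, so this single step is thin evidence. It points to no step beyond the scatter and to no firm direction.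

The estimated step is a 1.2-fold higher number from compound 2 to compound 4 (0.07 log units; within the scatter), which is expected to stay within the scatter. For compound 4 the expected value in this assay is 620 mL/min/kg, with an estimated range of 320 mL/min/kg to 1150 mL/min/kg.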

Compound 4, clearance: 767 mL/min/kg
The estimate for compound 4 lay 1.2-fold (0.09 log units) below the measured number, and the stated range covers the measured number.
By their numbers in this assay, from the lowest: compound 3; then compounds 2, 4 and 1 (each within the scatter of the next).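

In this assay the 5-fluoropyridin-2-yl group gives a 1.4-fold higher number from compound 2 to compound 4 (0.16 log units; within the scatter) and a 1.1-fold lower number from compound 1 to compound 4 (0.04 log units; within the scatter), so it joins the 3-fluoropyridin-2-yl and 4-fluoropyridin-2-yl groups with no step beyond the scatter. Compounds 1, 2 and 4 therefore show that, on this core and at this place, exchanging one of these three fluoropyridinyl groups for another does not separate the compounds on this read-out. Nothing measured here explains this result.

The compounds shown leave open whether a pyridin-2-yl group without fluorine, or an amine or a carboxylic acid on the pyridine ring, would give a step beyond the scatter at this place. They also leave open whether these fluoropyridinyl exchanges would stay within the scatter on the core of compound 3.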